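Extending a side-chain amine into a piperidine ring

This account rests on a few compounds, and the source may have more. Where it says the series, first, only, none or still open, it means among the compounds named here.

Measured compounds:
Compound 1 `CCOC(=O)C1=C(C)N/C(=C/c2cc(C)n(-c3ccc(CN(C)C)cc3)c2C)C1=O` gives 8.3 in a physicochemical assay for lipophilicity, read by HPLC, at pH 7.4; a lower number here means a more polar compound, a higher number a more lipophilic compound.
Compound 2 `CCOC(=O)C1=C(C)N/C(=C/c2cc(C)n(-c3cccc(OC)c3)c2C)C1=O` gives 2.9 in this assay.

Compound 1 stands highest of the two numbers measured; its nearest neighbour is compound 2, and the step of a number 5.40 log units lower from compound 1 to compound 2 (beyond the scatter) is large and beyond the usual scatter. That step, however, replaces the whole group on the aromatic nitrogen, and so says nothing directly about the change now considered.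

Compound 3 `CCOC(=O)C1=C(C)N/C(=C/c2cc(C)n(-c3ccc(CN4CCCCC4)cc3)c2C)C1=O` differs from compound 1 in one place only: piperidin-1-yl in place of dimethylamino on a saturated chain carbon bound to an aromatic carbon. Going by the values given here, no measured step covers this change, so the expectation rests on the structural difference alone, which exchanges a small open group for a six-membered saturated ring carrying more carbon.

Such a change is expected to raise the number in this assay modestly, by about a number 0.70 log units higher from compound 1 to compound 3 (beyond the scatter). For compound 3 the estimated value is therefore 9, with a plausible range from 8.2 to 9.8.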

Compound 3, distribution coefficient: 8.5
Beside the measured number, compound 3's estimate is 0.50 log units above it; the range from low to high includes it.
By their numbers in this assay, from the lowest: compound 2; then compounds 1 and 3 (each within the scatter of the next).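

In this assay, piperidin-1-yl in place of dimethylamino on a saturated chain carbon bound to an aromatic carbon gives a number 0.20 log units higher from compound 1 to compound 3 (within the scatter) and so leaves the two compounds indistinguishable in this measurement. This is the first comparison among the compounds shown that alters only the amine and keeps the rest of the molecule intact. Here, going from an open group of 3 heavy atoms to a six-membered non-aromatic ring of 6 heavy atoms produces no readable difference, and nothing available offers a reason for this. From the compounds shown here alone, whether other cyclic amines, such as pyrrolidine or morpholine, would behave the same way at this place remains open. So does the outcome with a carboxylic acid there, or with a longer chain carrying the piperidine.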